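Series notes: chain on the aromatic nitrogen, compounds 1 to 3

The source may report more compounds than this note shows. Statements on the series, on what has been measured and on what is new or still open speak of the compounds shown alone.

Measured so far in a functional assay on MCF7 cells (Homo sapiens) for cytotoxicity; a lower number here means that less compound is needed, a higher number that more compound is needed for the effect:
compound 1, `C#CCCn1c(Cc2cc(OC)c(OC)c(OC)c2)nc2c(N)nc(F)nc21`, gives 286000000 nM;
compound 2, `CC#CCCn1c(Cc2cc(OC)c(OC)c(OC)c2)nc2c(N)nc(F)nc21`, gives 95500000 nM.

For the measured compounds named here, compound 2 stands lowest of the two numbers; the only neighbour is compound 1, and the step of a 3.0-fold lower number from compound 1 to compound 2 (0.48 log units; beyond the scatter) runs beyond the scatter. Compound 3, `COc1cc(Cc2nc3c(N)nc(F)nc3n2CC2CCCO2)cc(OC)c1OC`, differs from compound 2 by oxolan-2-yl in place of but-2-yn-1-yl on a saturated chain carbon bound to an aromatic nitrogen. Going by the values given here, no measured step touches this exchange; only the step of a 3.0-fold lower number from compound 1 to compound 2 (0.48 log units; beyond the scatter) concerns the same chain, and it was modest. A step no larger than that is expected in this assay, direction uncertain. Compound 3 is therefore estimated at 100000000 nM, range 30000000 nM to 400000000 nM, a step of a 1.0-fold higher number from compound 2 to compound 3 (0.02 log units; within the scatter) expected.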

Compound 3, half-maximal effective concentration: 147000000 nM
Estimate against measurement, compound 3: 1.5-fold (0.17 log units) below; the measured number falls inside the stated range.
By their numbers in this assay, from the lowest: compounds 2, 3 and 1 (each within the scatter of the next, the first and the last beyond it).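

In this assay oxolan-2-yl in place of but-2-yn-1-yl gives a 1.5-fold higher number from compound 2 to compound 3 (0.19 log units; within the scatter) and in place of propargyl gives a 1.9-fold lower number from compound 1 to compound 3 (0.29 log units; within the scatter) on the same saturated chain carbon bound to an aromatic nitrogen. A chain end with a ring and an oxygen and no triple bond therefore sits within the scatter of both alkyne chains, so the triple bond is not required to hold the number at this level. No measurement at hand explains this.

The compounds shown span only a narrow band of numbers. Going by these compounds, whether an amine, a carboxylic acid or a longer chain at this place would leave that band remains open.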